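The source may hold more compounds than are shown below. What is called first, only, known or untested is meant among the compounds shown, and "the series" means these compounds.

Measured so far in a functional assay on isolated protein for agonist activity at Glucose-dependent insulinotropic receptor (Rattus norvegicus), read by HTRF and cAMP accumulation; on this read-out lower numbers stand for an effect already at smaller amounts and higher numbers for an effect only at larger amounts of compound:
- compound 1 `Cc1nc(S(C)(=O)=O)ccc1O[C@H]1CC[C@H](OC2CCN(C(=O)OC(C)C)CC2)CC1`: 89 nM
- compound 2 `CC(C)(C)OC(=O)N1CCC(O[C@H]2CC[C@H](Oc3cnc(C#N)cn3)CC2)CC1`: 28.4 nM
- compound 3 `CC1(OC(=O)N2CCC(O[C@H]3CC[C@H](Oc4cnc(S(C)(=O)=O)cn4)CC3)CC2)CC1`: 138 nM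

On these numbers, compound 3 sits close to compound 1, a gap within the usual scatter, while compound 2 gives a clearly lower number, a gap beyond it. Compound 4 `CS(=O)(=O)c1cnc(O[C@H]2CC[C@H](OC3CCN(C(=O)C4(C(F)(F)F)CCCC4)CC3)CC2)cn1` is not yet measured; it differs from compound 3 in one place: a group of 9 heavy atoms (6 carbon, 3 fluorine; one five-membered non-aromatic ring of carbon only) in place of a group of 5 heavy atoms (4 carbon, 1 oxygen; one three-membered non-aromatic ring of carbon only), on a carbonyl carbon. For the measured compounds named here, no measured pair shows this kind of exchange, so its effect is unknown. All three measured numbers fall within a modest span. Compound 4 is expected to land near compound 3, with the step of a 1.4-fold lower number from compound 3 to compound 4 (0.14 log units; within the scatter) possibly no larger than the scatter. The estimate for compound 4 in this assay is 100 nM, in the range 30 nM to 400 nM.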

Compound 4, half-maximal effective concentration: 108 nM
Compound 4: middle estimate off by 1.1-fold (0.03 log units), on the low side; the range from low to high includes it.
By their numbers in this assay, from the lowest: compound 2; then compounds 1, 4 and 3 (each within the scatter of the next).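

In this assay, putting a larger group with three fluorines and a five-membered carbon ring on the carbonyl carbon in place of (1-methylcyclopropyl)oxy gives a 1.3-fold lower number from compound 3 to compound 4 (0.11 log units; within the scatter), so this position accepts a clear change of group, including loss of the oxygen, without a shift beyond the scatter. No measurement here explains why the number holds.

On these data alone, the ring and the fluorines changed together, so their separate shares remain unknown. Also open, as far as these compounds go, is how an amine or a carboxylic acid would behave on this carbonyl carbon.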